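This account rests on a few compounds, and the source may have more. Where it says the series, first, only, none or still open, it means among the compounds named here.

Measured in a functional assay on HT-29 cells (Homo sapiens) for cytotoxicity, read by MTT assay, with a stated time of 72 h; a higher number here means a weaker inhibitor, a lower number a stronger inhibitor:
- Compound 1 `N[C@H]1CC[C@H](Nc2c(C(=O)NCc3ccc(F)cc3)nc(N3CCCCS3(=O)=O)c3cccnc23)CC1`: > 10000 nM, a limit
- Compound 2 `NCCCNc1c(C(=O)NCc2ccc(F)cc2)nc(Br)c2cccnc12`: "not determined" (no result reported)
- Compound 3 `N[C@H]1CC[C@H](Nc2c(C(=O)NCc3ccc(F)cc3)nc(Br)c3cccnc23)CC1`: < 1000 nM, a limit

Compound 3 stands at < 1000 nM, which is a limit and not a number. Compound 4 `COC(=O)CNc1c(C(=O)NCc2ccc(F)cc2)nc(Br)c2cccnc12` carries (methoxycarbonyl)methyl in place of 4-aminocyclohexyl on a nitrogen on an aromatic ring. For the measured compounds named here, no measured step touches this group, since compound 2 gives no result. Going by the values given here, the one measured step, an at least 10-fold lower number from compound 1 to compound 3 (1.00 log units; beyond the scatter), lies elsewhere on the molecule, yet it shows that a single swap can move readings in this assay far. On that thin support, a move towards a higher number, a weaker inhibitor, is expected, and the expected size is an at least 4.0-fold higher number from compound 3 to compound 4 (0.60 log units; beyond the scatter). For compound 4 the estimated value is 4000 nM, with an expected range of 800 nM to 20000 nM.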

Compound 4, half-maximal inhibitory concentration: > 10000 nM
Compound 4 ended at the assay's limit; the forecaster's own chance of this, stated with the estimate: 45%; at least 2.5-fold (0.39 log units) between middle value and limit.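

In this assay, the group on this nitrogen proves able to move the reading far: (methoxycarbonyl)methyl in place of 4-aminocyclohexyl gives an at least 10-fold higher number from compound 3 to compound 4 (1.00 log units; beyond the scatter). For the compounds shown here, this is the first measured step at this position, made with the bromine held fixed. Both readings are limits, so the step has a lower bound but no exact size.

Still open, going by these compounds, is whether the ring or its amine matters more. A plain cyclohexyl would separate the two, and compound 2, with its open-chain amine, gives no result to settle this.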